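A few compounds are considered here, and "the series" means these few. Any claim that something is new, unique, unknown or untested is made for them only; others in the source may bear on it.

In an in vitro assay on HEK293 cells for displacement of a labelled ligand from adenosine receptor A2b (Homo sapiens) (on this read-out lower numbers stand for stronger inhibition and higher numbers for weaker inhibition), the series rests on two numbers and one limit. Compound 3 `CCn1c(=O)c2nc(-c3cnn(Cc4ccccc4)c3)[nH]c2n(CC)c1=O` gives 19 nM. Compound 2 `CCCn1c(=O)c2nc(-c3cnn(Cc4cccc(C)c4)c3)[nH]c2n(CCC)c1=O` gives 36 nM, and the gap between compound 2 and compound 3 lies within the usual scatter of repeated measurements, so the two are not told apart by this assay. Compound 1 `CCCn1c(=O)c2nc(-c3cnn(-c4ccccc4)c3C(F)(F)F)[nH]c2n(CCC)c1=O` is reported only as a limit of this assay, > 6600 nM, which is where the limit of > 6600 nM in this assay, at which 1 of the 3 values shown sits, sits.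

The next step leads from compound 2 to compound 4 `CCCn1c(=O)c2nc(-c3cnn(Cc4ccc(F)cc4F)c3)[nH]c2n(CCC)c1=O`. The difference between the two, (2,4-difluorophenyl in place of 3-methylphenyl on a saturated chain carbon bound to an aromatic nitrogen), keeps the saturated chain carbon bound to an aromatic nitrogen and the rest of the shared core unchanged. Among the compounds with values here, no measured step in this assay separates a 3-methylbenzyl group from a 2,4-difluorobenzyl group, so the size of this step is not known from the data.

Given that compound 2 with its 36 nM and compound 3 with its 19 nM sit within the scatter of each other, the expectation for compound 4 is a step of a 1.2-fold lower number from compound 2 to compound 4 (0.08 log units; within the scatter), with no direction beyond the scatter. Compound 4 is therefore estimated at 30 nM in this assay, expected to fall between 10 nM and 100 nM.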

Compound 4, inhibition constant: 700 nM
The estimate for compound 4 lay 23-fold (1.37 log units) below the measured number; measured number outside the range, above it.
By their numbers in this assay, from the lowest: compounds 3 and 2 (each within the scatter of the next); then compound 4. At a limit, above all of these: compound 1.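

In this assay, the change from 3-methylbenzyl to 2,4-difluorobenzyl proves large, with a 19-fold higher number from compound 2 to compound 4 (1.29 log units; beyond the scatter), although the saturated chain carbon bound to an aromatic nitrogen and the shared core stay the same. Within the data shown here, this gives the first step between measured compounds that differ in one place, and it shows that the substituents on the phenyl ring at this position can by themselves move the number well beyond the scatter: a benzyl group here is not enough to keep the number of compound 2. Nothing measured for these compounds accounts for the size of this step.

The single change removes the methyl group and brings in both fluorines, so the compounds shown do not tell which of these differences carries the step, or whether one fluorine alone would give the same result. They also leave open how a phenyl ring bearing a methoxy group, a nitrile or a dimethylamino group on the same chain carbon would read in this assay.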